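Bromo-Hydroxyphenyl Replaces Bromo-Fluorophenyl on a Hydrazone

The source may hold more compounds than are shown below. What is called first, only, known or untested is meant among the compounds shown, and "the series" means these compounds.

Compound 1, `Cn1c(=O)c(=O)n(C2CCCC2)c2nc(N/N=C/c3ccccc3)ncc21`: 48200 nM
Compound 2, `Cn1c(=O)c(=O)n(C2CCCC2)c2nc(N/N=C/c3ccc(Cl)cc3)ncc21`: 8420 nM
Compound 3, `Cn1c(=O)c(=O)n(C2CCCC2)c2nc(N/N=C/c3ccc(F)cc3Br)ncc21`: 9250 nM

All three were tested in a functional assay on PC-3 cells (Homo sapiens) for antiproliferative activity, read by MTT assay; a lower number here means a stronger inhibitor, a higher number a weaker inhibitor. Compound 3 sits second highest of the three numbers; the steps leading to it were a 5.2-fold lower number from compound 1 to compound 3 (0.72 log units; beyond the scatter) and a 1.1-fold higher number from compound 2 to compound 3 (0.04 log units; within the scatter). Compound 4, `Cn1c(=O)c(=O)n(C2CCCC2)c2nc(N/N=C/c3ccc(O)c(Br)c3)ncc21`, carries a single change: 3-bromo-4-hydroxyphenyl in place of 2-bromo-4-fluorophenyl on a carbon with a double bond to nitrogen. Among the measured compounds shown here, no measured step introduces a hydrogen-bond donor, so the closest guide is the exchange of one substituted phenyl for another, a 1.1-fold higher number from compound 2 to compound 3 (0.04 log units; within the scatter), which stayed within the scatter, while both substituted phenyls gave lower numbers than plain phenyl (a 5.7-fold lower number from compound 1 to compound 2 (0.76 log units; beyond the scatter)). A small step is therefore expected, a 1.2-fold lower number from compound 3 to compound 4 (0.06 log units; within the scatter), possibly none beyond the scatter. Compound 4 is estimated at 8000 nM, within 2500 nM to 25000 nM.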

Compound 4, half-maximal inhibitory concentration: 11600 nM
Estimate against measurement, compound 4: 1.5-fold (0.16 log units) below; the range from low to high includes it.
By their numbers in this assay, from the lowest: compounds 2, 3 and 4 (each within the scatter of the next); then compound 1.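

Exchanging 2-bromo-4-fluorophenyl for 3-bromo-4-hydroxyphenyl adds a hydrogen-bond donor on the carbon with a double bond to nitrogen, yet the result is only a 1.3-fold higher number from compound 3 to compound 4 (0.10 log units; within the scatter). Against the 4-chlorophenyl compound the result is likewise small (a 1.4-fold higher number from compound 2 to compound 4 (0.14 log units; within the scatter)), while the difference from plain phenyl remains clear (a 4.2-fold lower number from compound 1 to compound 4 (0.62 log units; beyond the scatter)). Nothing available explains this result.

On these data alone, whether an amine or a carboxylic acid on this phenyl ring would also leave the number unchanged remains open. So does the outcome for a longer chain there.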